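Replacing the benzyl group on compound 2 with a thiazolylsulfanylethyl chain

This account rests on a few compounds, and the source may have more. Where it says the series, first, only, none or still open, it means among the compounds named here.

In a functional assay (trachea) with Cavia porcellus as the target (on this read-out lower numbers stand for stronger inhibition and higher numbers for weaker inhibition), compound 1 `CCCn1nc(-c2cccnc2)c2ccccc2c1=O` gives 3160 nM, and compound 2 `O=c1c2ccccc2c(-c2cccnc2)nn1Cc1ccccc1` gives 2450 nM. For the measured compounds named here, compound 2 holds the lower of the two numbers, yet the only measured step, a 1.3-fold lower number from compound 1 to compound 2 (0.11 log units; within the scatter), leaves the two compounds indistinguishable within the scatter. Compound 3 `O=c1c2ccccc2c(-c2cccnc2)nn1CCSc1nccs1` has not been measured in this assay. It differs from compound 2 by ((1,3-thiazol-2-yl)sulfanyl)methyl in place of phenyl on a saturated chain carbon bound to an aromatic nitrogen. Going by the values given here, the one measured step concerns the same position but exchanges ethyl for phenyl, which gave no change beyond the scatter; no measured pair speaks to the entering ((1,3-thiazol-2-yl)sulfanyl)methyl group. The numbers seen so far therefore give no basis for expecting a step beyond the scatter, and the expected step is a 1.1-fold lower number from compound 2 to compound 3 (0.05 log units; within the scatter). Compound 3 is estimated to give 2200 nM in this assay, with a range from 600 nM to 8000 nM.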

Compound 3, half-maximal inhibitory concentration: 10500 nM
For compound 3 the middle estimate is 4.8-fold (0.68 log units) below the measured one; the measured number lies above the stated range.
By their numbers in this assay, from the lowest: compounds 2 and 1 (each within the scatter of the next); then compound 3.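

The position on the saturated chain carbon bound to an aromatic nitrogen is not indifferent to every group: the earlier exchange stayed within the scatter, but in this assay the change from benzyl to 2-((1,3-thiazol-2-yl)sulfanyl)ethyl gives a 4.3-fold higher number from compound 2 to compound 3 (0.63 log units; beyond the scatter) and thus weaker inhibition. Placing (1,3-thiazol-2-yl)sulfanyl in place of methyl on a saturated chain carbon, two bonds along the chain from an aromatic nitrogen, gives a 3.3-fold higher number from compound 1 to compound 3 (0.52 log units; beyond the scatter) in the same direction. Nothing available accounts for this weakening.

The compounds shown do not separate the contribution of the sulfur link from that of the thiazole ring. They also leave open how this position would respond to an amine, a carboxylic acid or a plain phenyl on a longer chain.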